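Changing the Halogenated Benzyl Group from Compound 2 to Compound 4

This account rests on a few compounds, and the source may have more. Where it says the series, first, only, none or still open, it means among the compounds named here.

Compound 1 `CCOC(=O)[C@H](CCC(=O)O)NC(=O)c1ccc(CNc2nc3cc(N)cc(N)c3nc2-c2ccccc2)cc1`: < 100000 nM
Compound 2 `Nc1cc(N)c2nc(-c3ccccc3)c(NCc3ccc(Cl)c(Cl)c3)nc2c1`: 29500 nM
Compound 3 `COc1cc(CNc2nc3cc(N)cc(N)c3nc2-c2ccccc2)cc(OC)c1OC`: < 50200 nM

Three compounds sharing one core were tested in a functional assay on IGROV-1 cells (Homo sapiens) for inhibition, read by sulforhodamine B assay, with a stated time of 48 h; a higher number here means that more compound is tolerated, a lower number that less compound is tolerated. Compound 1 reached only the limit of < 100000 nM, which is a boundary of the assay and not a number. Compound 3 likewise stopped at a limit, < 50200 nM. Among the compounds with values here, that leaves compound 2, with 29500 nM, as the only true number in the set. Compound 1 sits at a limit (the limit of < 100000 nM in this assay, at which 1 of the 3 values shown sits). Compound 3 sits at a limit (the limit of < 50200 nM in this assay, at which 1 of the 3 values shown sits). Compound 2 therefore cannot be ranked against either of them.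

Compound 4 `Nc1cc(N)c2nc(-c3ccccc3)c(NCc3ccc(F)cc3)nc2c1` has not yet been measured. It differs from compound 2 in one place: 4-fluorophenyl in place of 3,4-dichlorophenyl on a saturated chain carbon bound to a nitrogen on an aromatic ring. Within the data shown here, no measured pair in this set shows the same change, so there is no direct guide to its size. Among the measured compounds shown here, since the only solid number is compound 2 at 29500 nM, the expectation for compound 4 is anchored there, with a modest shift toward more tolerated compound that may not exceed the usual scatter; the expected step of a 1.4-fold higher number from compound 2 to compound 4 (0.13 log units; within the scatter) is small. Compound 4 is expected to give about 40000 nM, within a range from 15000 nM to 100000 nM.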

Compound 4, concentration lethal to 50% of the cells: < 100000 nM
Compound 4 gave a limit, no number; the forecaster's own chance of this, stated with the estimate: 35%; the middle value lies beyond the limit too.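

Within the data shown here, compound 4 gives < 100000 nM, which is a limit and not a number, so no step from compound 2 to compound 4 can be read. The compounds shown leave open whether 4-fluorophenyl in place of 3,4-dichlorophenyl shifts the value at all, and how compound 1, compound 3 and compound 4, all stopped at limits, rank against one another.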